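The source may report more compounds than this note shows. Statements on the series, on what has been measured and on what is new or still open speak of the compounds shown alone.

Working notes on the hydrazone series sharing one core.

Compound 1 `COc1cc(/C=N/NC(=O)CCCc2nc3ccccc3c(=O)[nH]2)cc(O)c1O` gives 50000000 nM in a physicochemical assay, read by spectrophotometry, with a stated time of 6 min; a higher number here means a weaker inhibitor, a lower number a stronger inhibitor. Compound 2 `O=C(CCc1nc2ccccc2c(=O)[nH]1)N/N=C/c1ccc(Cl)cc1` gives 185000000 nM in this assay, and compound 3 `O=C(CCCc1nc2ccccc2c(=O)[nH]1)N/N=C/c1ccc([N+](=O)[O-])cc1` gives 270000000 nM. Among these three numbers compound 2 stands second highest; its gap to compound 3 lies within the scatter, so no order is claimed between those two, while its gap to compound 1 lies beyond the scatter, compound 1 showing the lower number.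

Compound 4 `O=C(CCc1nc2ccccc2c(=O)[nH]1)N/N=C/c1ccc(O)c(O)c1` is not yet measured. It differs from compound 2 in one place (3,4-dihydroxyphenyl in place of 4-chlorophenyl on a carbon with a double bond to nitrogen).

Going by the values given here, no step between measured compounds that differ in a single place is available, so the expectation rests on the whole set. A downward step from compound 2 to compound 4, of moderate size and beyond the scatter, is expected a 3.1-fold lower number from compound 2 to compound 4 (0.49 log units; beyond the scatter), because compound 1, which also carries hydroxyl groups on its aryl ring, shows 50000000 nM, the lowest number here. Compound 4 is accordingly estimated at 60000000 nM, with a range from 25000000 nM to 150000000 nM.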

Compound 4, half-maximal inhibitory concentration: 40000000 nM
The estimate for compound 4 lay 1.5-fold (0.18 log units) above the measured number; measured number inside the range.
By their numbers in this assay, from the lowest: compounds 4 and 1 (each within the scatter of the next); then compounds 2 and 3 (each within the scatter of the next).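

Going by these compounds alone, compound 2 and compound 4 give the first single-place comparison: 3,4-dihydroxyphenyl in place of 4-chlorophenyl on a carbon with a double bond to nitrogen gives a 4.6-fold lower number from compound 2 to compound 4 (0.67 log units; beyond the scatter) in this assay with the rest of the structure held constant. The earlier compounds shown here could not show this, since none of them differ in one place only, and the aryl group could not be separated from the rest of each structure. This place therefore responds to this change beyond the scatter, but nothing measured here accounts for the step.

From the compounds shown here alone, it remains open whether a single hydroxyl group would give a comparable step, or whether the same step holds with the chain of compound 1. An amine or a carboxylic acid on the aryl ring also remains an open case.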